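Swapping the halogenated ring on a shared core

The source may report more compounds than this note shows. Statements on the series, on what has been measured and on what is new or still open speak of the compounds shown alone.

Measured so far:
compound 1, `C=CCn1c(=O)/c(=C\c2ccccc2Cl)[nH]c(=O)/c1=C\c1ccccc1OC`: 9200 nM in a functional assay on NCI-H1975 cells (Homo sapiens) for cytotoxicity, read by CCK-8 assay, with a stated time of 72 h; a lower number here means a stronger inhibitor, a higher number a weaker inhibitor
compound 2, `C=CCn1c(=O)/c(=C\c2ccc(Cl)c(Cl)c2)[nH]c(=O)/c1=C\c1ccccc1OC`: "not active" (no number reported) in this assay, with no number given

The two measured compounds share one core and differ only in the ring carried on the double-bonded chain carbon. Compound 1 is a weak inhibitor in this assay, giving 9200 nM. For the measured compounds named here, compound 2 stands outside the numbers altogether: in this assay compound 2 was recorded as "not active" (no number reported), so no value can be placed beside it and no step to compound 1 can be sized.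

Compound 3, `C=CCn1c(=O)/c(=C\c2cc(Br)ccc2F)[nH]c(=O)/c1=C\c1ccccc1OC`, differs from compound 2 by 5-bromo-2-fluorophenyl in place of 3,4-dichlorophenyl on a double-bonded chain carbon bound to an aromatic carbon. Going by the values given here, with no measured step between compounds available, the size of this change in this assay cannot be anchored; the only footing is that compound 1 is weak and compound 2 gave nothing. Compound 3 is therefore expected to remain weak in this assay, with a real chance that no number is reported for it either. The estimate for compound 3 is 15000 nM, with a range from 4000 nM to 60000 nM.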

Compound 3, half-maximal inhibitory concentration: "not active" (no number reported)
The entry for compound 3 holds no number, and the estimate cannot be compared.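

For the compounds shown here, compound 2 and compound 3 are both recorded as "not active" with no number, so no step between them can be read. No available evidence bears on this result. The compounds shown leave open how far either lies from compound 1 at 9200 nM.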